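This account rests on a few compounds, and the source may have more. Where it says the series, first, only, none or still open, it means among the compounds named here.

Compound 3, `C1=C(CCN2CCN(c3cccc4c3OCCO4)CC2)c2ccccc2C1`, stands in a functional assay on the whole organism for agonist activity, with Rattus norvegicus as the target (a higher number here means that more compound is needed for the effect, a lower number that less compound is needed), only at a limit: compound 3 gives > 2.5 mg/kg, and no number lies behind it. Two close relatives carry real values. Compound 1, `c1ccc2c(c1)CCC2CCCN1CCN(c2cccc3c2OCCO3)CC1`, gives in this assay 10 mg/kg. Compound 2, `c1ccc2c(c1)CC2CCCN1CCN(c2cccc3c2OCCO3)CC1`, gives in this assay 10 mg/kg. The step of no change at the digits printed from compound 1 to compound 2 (within the scatter) shows that swapping the fused ring at the end of the chain, with the chain kept at the same length, leaves the dose where it was. The step that the limit leaves unreadable from compound 2 to compound 3 cannot be sized, since compound 3 sits at the limit of > 2.5 mg/kg in this assay, at which 1 of the 3 values shown sits.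

The new compound is compound 4, `c1ccc2c(c1)CCC2CCN1CCN(c2cccc3c2OCCO3)CC1`. Its difference from compound 3 is a group of 9 heavy atoms (9 carbon; one five-membered non-aromatic ring of carbon only, one six-membered aromatic ring of carbon only) in place of a group of 9 heavy atoms (9 carbon; one five-membered non-aromatic ring of carbon only, one six-membered aromatic ring of carbon only), on a saturated chain carbon, two bonds along the chain from an amine nitrogen in a ring. Among the measured compounds shown here, no measured step covers this exact change: the one readable step, from compound 1 to compound 2, concerns a different part of the molecule and was flat, while the step into compound 3 is hidden by the limit. He therefore has no ground to expect any direction beyond the scatter, and the estimate is anchored loosely to the doses of compounds 1 and 2. Compound 4 is expected to give about 5 mg/kg, within 2 mg/kg to 15 mg/kg, which would mean a step that the limit leaves unreadable from compound 3 to compound 4, with a real chance that only a limit is again reported.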

Compound 4, minimum effective dose: > 40 mg/kg
Compound 4 was reported as a limit; the forecaster's own chance of this, stated with the estimate: 40%; middle value at least 8.0-fold (0.90 log units) from the limit.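

In this assay compound 4, which carries 2,3-dihydro-1H-inden-1-yl on a saturated chain carbon, two bonds along the chain from an amine nitrogen in a ring, is reported only as a limit: the limit of > 40 mg/kg in this assay, at which 1 of the 4 values shown sits.

Even so, this place now yields a readable change, an at least 4.0-fold higher number from compound 2 to compound 4 (0.60 log units; beyond the scatter), whereas the only readable step before it, no change at the digits printed from compound 1 to compound 2 (within the scatter), was flat and lay on a saturated chain carbon three bonds along the chain from the amine nitrogen. The steps into and out of compound 3 cannot be read, so the double bond outside aromatic rings that leaves with compound 3 cannot be given any effect on the dose.

The compounds shown leave open how large the step to compound 4 really is, since only its lower bound can be read. They also leave open whether a longer chain at this place, or a hydroxyl group or an amine on the five-membered non-aromatic ring of the 2,3-dihydro-1H-inden-1-yl group, would bring the dose back down.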